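Adding a fluoro to compound 2 at the assay limit

The source may report more compounds than this note shows. Statements on the series, on what has been measured and on what is new or still open speak of the compounds shown alone.

Measured so far in a functional assay on CCRF-CEM cells (Homo sapiens) for cytotoxicity, in the presence of a further agent that is not named here; a lower number here means a stronger inhibitor, a higher number a weaker inhibitor:
Compound 1 `COC(=O)c1ccc(CN(CCCc2c(N)nc(N)nc2O)c2cc(F)cc(F)c2[N+](=O)[O-])cc1` gives > 100000 nM (a limit)
Compound 2 `Nc1nc(N)c(CCCNc2cc(F)ccc2[N+](=O)[O-])c(O)n1` gives > 100000 nM (a limit)
Compound 3 `COC(=O)c1ccc(CN(CCCc2c(N)nc(N)nc2O)c2cc(F)c(F)cc2[N+](=O)[O-])cc1` gives 53000 nM (a number)

Compound 2 has no exact number in this assay and stands with compound 1 at one shared ceiling (the limit of > 100000 nM in this assay, at which 2 of the 3 values shown sit). Compound 4 `Nc1nc(N)c(CCCNc2cc(F)cc(F)c2[N+](=O)[O-])c(O)n1` is compound 2 with one change: fluoro in place of hydrogen on an aromatic carbon.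

Among the measured compounds shown here, no measured step makes this exact change. The closest evidence moves a fluoro between two places on the ring of a larger compound, and it is an at least 1.8-fold lower number from compound 1 to compound 3 (0.27 log units; that floor lies within the scatter) (a step whose floor does not clear the scatter). That step therefore gives no firm sign of how much fluoro placement matters. Compound 1 has the same fluoro pattern as compound 4, and compound 1 gives > 100000 nM (a limit).

On this evidence, no step beyond the scatter is expected, and the estimated change is a number no higher from compound 2 to compound 4 (the limit leaves the size open) (likely to be hidden by the ceiling). For compound 4 the estimate is 100000 nM (expected range 40000 nM to 250000 nM), and a reading that is again only a limit is the likeliest result.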

Compound 4, half-maximal inhibitory concentration: 94000 nM
For compound 4 the middle estimate is 1.1-fold (0.03 log units) above the measured one, within the range that was stated.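

In this assay compound 4 gives 94000 nM, a real number rather than a limit, so the series without the group on the nitrogen now has one measured point. Adding the fluoro on this carbon, ortho to a nitro group, gives an at least 1.0-fold lower number from compound 2 to compound 4 (0.02 log units; that floor lies within the scatter), and taking away the 4-(methoxycarbonyl)benzyl in favour of hydrogen gives an at least 1.0-fold lower number from compound 1 to compound 4 (0.02 log units; that floor lies within the scatter). Neither change can yet be given a firm size or even a firm direction, because each of these steps starts from a compound with no exact value and the true distance could be small or large: the limit of > 100000 nM in this assay, at which 2 of the 4 values shown sit.

The compounds shown leave open whether another group on this same carbon, such as chloro, methoxy or an amine, would give a number clearly away from that ceiling. They also leave open whether a longer chain to the core, or a carboxylic acid in place of the ester on the benzyl group, would change the picture in a way that could be read beyond the scatter.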